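Isoxazole in place of tolyl on a free fatty acid receptor agonist

This account rests on a few compounds, and the source may have more. Where it says the series, first, only, none or still open, it means among the compounds named here.

Compound 3 `Cc1ccccc1-c1cccc(COc2ccc(S(=O)(=O)CC(=O)O)cc2)c1` gives 46.8 nM in a functional assay on CHO cells for agonist activity at Free fatty acid receptor 1 (Homo sapiens), read by FLIPR and calcium flux (on this read-out lower numbers stand for an effect already at smaller amounts and higher numbers for an effect only at larger amounts of compound), the higher of the two numbers that were obtained. Compound 1 `Cc1cc(OCCCS(C)(=O)=O)cc(C)c1-c1cccc(COc2ccc(CCC(=O)O)cc2)c1` gives 15.5 nM, a lower number beyond the scatter. Compound 2 `CO/N=C1\CC(CC(=O)O)c2ccc(OCc3cccc(-c4c(C)cc(OC)cc4C)c3)cc21` reaches only the limit > 1000 nM, a limit rather than a number (the limit of > 1000 nM in this assay, at which 1 of the 3 values shown sits). Compound 4 `Cc1noc(C)c1-c1cccc(COc2ccc(S(=O)(=O)CC(=O)O)cc2)c1` has not been measured; it differs from compound 3 by 3,5-dimethyl-1,2-oxazol-4-yl in place of 2-methylphenyl on an aromatic carbon. For the measured compounds named here, no measured pair tells the size of such a change. Compound 4 is expected to lie close to compound 3, with a small shift toward a higher number that may not exceed the scatter, giving an estimated 1.7-fold higher number from compound 3 to compound 4 (0.23 log units; within the scatter). Compound 4 is thus estimated at 80 nM, between 25 nM and 300 nM.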

Compound 4, half-maximal effective concentration: 269 nM
Compound 4: middle estimate off by 3.4-fold (0.53 log units), on the low side; the measured number falls inside the stated range.
By their numbers in this assay, from the lowest: compound 1; then compound 3; then compound 4. At a limit, above all of these: compound 2.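

At this aromatic carbon, meta to a large group, 3,5-dimethyl-1,2-oxazol-4-yl in place of 2-methylphenyl gives in this assay a 5.7-fold higher number from compound 3 to compound 4 (0.76 log units; beyond the scatter), the only single-place change shown. The read-out thus tells the five-membered aromatic ring with 2 hetero atoms from the six-membered ring of carbon only, although both groups have 7 heavy atoms. Nothing in the data shown accounts for this step.

From the compounds shown here alone, whether a pyridine or an unsubstituted phenyl here would stand nearer to compound 3 or to compound 4 remains open. So does whether the step would carry over to the core of compound 1.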